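This account rests on a few compounds, and the source may have more. Where it says the series, first, only, none or still open, it means among the compounds named here.

The three measured compounds, each in an ADME assay on L929 cells (Mus musculus) for cytotoxicity, read by resazurin assay, with a stated time of 72 h; on this read-out lower numbers stand for stronger inhibition and higher numbers for weaker inhibition:
Compound 1, `Cc1cccc(C(=O)/C=C/c2ccc3c(c2)B(O)OC3)c1`, gives 8.56 ug/mL.
Compound 2, `O=C(/C=C/c1ccc2c(c1)B(O)OC2)c1ccc(F)cc1`, gives > 10 ug/mL, and that value is a limit of this assay rather than a number.
Compound 3, `O=C(/C=C/c1ccc2c(c1)B(O)OC2)c1cccc(O)c1`, gives 7.56 ug/mL.

All three share one core and differ only in the aromatic ring joined to the carbonyl. Compound 2 stands apart in that only a limit is known for it, (the limit of > 10 ug/mL in this assay, at which 1 of the 3 values shown sits), so its place among the numbers is open. The steps touching it are an at least 1.1-fold higher number from compound 1 to compound 2 (0.06 log units; that floor lies within the scatter) and an at least 1.3-fold lower number from compound 2 to compound 3 (0.12 log units; that floor lies within the scatter), and the step between the two fully measured compounds is a 1.1-fold lower number from compound 1 to compound 3 (0.05 log units; within the scatter); none of these reaches beyond the scatter.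

Compound 4, `CC(=O)Nc1ccc(C(=O)/C=C/c2ccc3c(c2)B(O)OC3)cc1`, is compound 2 with acetamido in place of fluoro on an aromatic carbon. This change sits on the same aromatic ring that was varied in the measured steps, and those steps were all small. I therefore expect no step beyond the scatter, so that the estimated step is an at least 1.1-fold lower number from compound 2 to compound 4 (0.04 log units; that floor lies within the scatter). Compound 4 is expected to come out near 9 ug/mL, with a range from 5 ug/mL to 18 ug/mL.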

Compound 4, half-maximal inhibitory concentration: > 10 ug/mL
Compound 4 ended at the assay's limit; the forecaster's own chance of this, stated with the estimate: 40%; at least 1.1-fold (0.04 log units) between middle value and limit.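

Compound 2 and compound 4 both end at a limit of this assay rather than at a number, so no step between them can be read: the limit of > 10 ug/mL in this assay, at which 2 of the 4 values shown sit.

The compounds shown leave open whether acetamido in place of fluoro on the aromatic carbon changes the read-out at all, and by how much.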